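Replacing the Octyl Part of a Long Side Chain

A few compounds are considered here, and "the series" means these few. Any claim that something is new, unique, unknown or untested is made for them only; others in the source may bear on it.

In an ADME assay on A549 cells (Homo sapiens) for cytotoxicity, read by MTT assay (a lower number here means that less compound is tolerated, a higher number that more compound is tolerated), compound 1 `CCCCCCCCNc1nc(=O)n([C@H]2C[C@H](O)[C@@H](CO)O2)cc1C` gives 90000 nM and compound 2 `CCCCCCCCCCNc1nc(=O)n([C@H]2C[C@H](O)[C@@H](CO)O2)cc1C` gives 156000 nM. Among the measured compounds shown here, compound 2 therefore stands level with compound 1, the only other compound measured so far, and the gap between them lies within the usual scatter. Compound 3 `COCCOCCOCCNc1nc(=O)n([C@H]2C[C@H](O)[C@@H](CO)O2)cc1C` has not yet been measured. It differs from compound 2 as follows: 2-(2-methoxyethoxy)ethoxy in place of octyl on a saturated chain carbon, two bonds along the chain from a nitrogen on an aromatic ring. In words, 2-(2-methoxyethoxy)ethoxy stands in place of octyl on a saturated chain carbon, two bonds along the chain from a nitrogen on an aromatic ring. For the measured compounds named here, the one measured step, a 1.7-fold higher number from compound 1 to compound 2 (0.24 log units; within the scatter), only lengthens a carbon chain and brings in no oxygen, so it offers weak guidance here. It does show a small change for a chain edit, so only a slight drift toward a higher number is expected, not clearly beyond the scatter. The estimated step is a 1.6-fold higher number from compound 2 to compound 3 (0.20 log units; within the scatter). Compound 3 is expected at 250000 nM, with an estimated range of 100000 nM to 700000 nM.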

Compound 3, half-maximal cytotoxic concentration: 90000 nM
Compound 3: the middle estimate sits 2.8-fold (0.44 log units) above what was measured; measured number outside the range, below it.
By their numbers in this assay, from the lowest: compounds 1, 3 and 2 (each within the scatter of the next).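

In this assay, 2-(2-methoxyethoxy)ethoxy in place of octyl gives a 1.7-fold lower number from compound 2 to compound 3 (0.24 log units; within the scatter), and the comparison with the shorter alkyl chain gives no change at the digits printed from compound 1 to compound 3 (within the scatter). The earlier pair differed only in the length of an all-carbon chain, whereas this result shows that a chain carrying oxygen atoms at this position, on a saturated chain carbon, two bonds along the chain from a nitrogen on an aromatic ring, stays within the scatter of both all-carbon compounds. Nothing measured here offers an explanation for this result.

On these data alone, whether an amine or a carboxylic acid at the end of this chain would take the number beyond the scatter remains open. So does the outcome for a much longer chain, whether built only from carbon or with further oxygen atoms.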